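The source may report more compounds than this note shows. Statements on the series, on what has been measured and on what is new or still open speak of the compounds shown alone.

Working notes on the series, step from compound 2 to compound 3.

Of the compounds shown here, two carry numbers so far. Compound 1 `CC(C)n1nc(-c2cc(-c3ccccn3)on2)c(C(N)=O)c1N` in an assay on isolated protein for inhibition of proto-oncogene tyrosine-protein kinase receptor Ret (Homo sapiens), read by radiometric assay and 33P incorporation, in the presence of a further agent that is not named here (on this read-out lower numbers stand for stronger inhibition and higher numbers for weaker inhibition), gives 4800 nM; compound 2 `CCc1cc(-c2nn(C(C)C)c(N)c2C(N)=O)no1` in this assay gives 631 nM. Going by the values given here, the one measured step, a 7.6-fold lower number from compound 1 to compound 2 (0.88 log units; beyond the scatter), exchanges a ring for a short chain on the aromatic carbon of the shared core. Among the compounds with values here, compound 2 therefore stands at the lowest of the two numbers, with compound 1 as its only neighbour at a clearly higher value.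

Compound 3 `CC(C)c1cc(-c2nn(C(C)C)c(N)c2C(N)=O)no1` is the next candidate. Relative to compound 2 the change is methyl in place of hydrogen on a saturated chain carbon bound to an aromatic carbon and a saturated chain carbon, or, cut one bond further out, ethyl to isopropyl. Within the data shown here, no measured pair probes this kind of change; the only step on record, a 7.6-fold lower number from compound 1 to compound 2 (0.88 log units; beyond the scatter), alters the same aromatic carbon but swaps a ring for a chain rather than lengthening a chain, so it shows the site is sensitive without fixing a direction for a single added methyl. The expected step for this assay is therefore small, a 1.3-fold lower number from compound 2 to compound 3 (0.10 log units; within the scatter), not clearly beyond the scatter. Compound 3 is estimated at 500 nM, within 200 nM to 1600 nM.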

Compound 3, half-maximal inhibitory concentration: 1260 nM
For compound 3 the middle estimate is 2.5-fold (0.40 log units) below the measured one, and the stated range covers the measured number.
By their numbers in this assay, from the lowest: compounds 2 and 3 (each within the scatter of the next); then compound 1.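

Adding a methyl on the saturated chain carbon bound to an aromatic carbon and a saturated chain carbon, which turns ethyl into isopropyl, gives a 2.0-fold higher number from compound 2 to compound 3 (0.30 log units; within the scatter) in this assay; compound 2 and compound 3 therefore cannot be told apart on this read-out, and this one branching change leaves the number inside the usual spread of repeats. The earlier contrast between a ring and a chain now rests on a second chain, since exchanging the ring for isopropyl gives a 3.8-fold lower number from compound 1 to compound 3 (0.58 log units; beyond the scatter) and both compound 2 and compound 3 read clearly lower than compound 1, with no compound shown going against this. No supporting data accompany these numbers, so nothing here explains either step.

Still open, going by these compounds, is whether a longer chain such as n-butyl, or a cyclopropyl, an amine or a carboxylic acid on the same aromatic carbon, would read apart from ethyl and isopropyl. On these data alone, the rest of the shared core is the same in all three compounds, so what changes there would do to the number in this assay remains unknown.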